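From 3-nitrophenyl to 4-nitrophenyl: notes on compound 3

A few compounds are considered here, and "the series" means these few. Any claim that something is new, unique, unknown or untested is made for them only; others in the source may bear on it.

In a functional assay on NSCLC cells (Homo sapiens) for antiproliferative activity (on this read-out higher numbers stand for weaker inhibition and lower numbers for stronger inhibition), compound 1 `N#CN/C(=N\CCCCCCOc1cccc(Cl)c1)Nc1ccncc1` gives 6.1 nM and compound 2 `N#CN/C(=N\CCCCCCOc1cccc([N+](=O)[O-])c1)Nc1ccncc1` gives 5.7 nM. Compound 2 therefore stands level with compound 1, and neither can be ranked above the other. The next structure is compound 3 `N#CN/C(=N\CCCCCCOc1ccc([N+](=O)[O-])cc1)Nc1ccncc1`, with the change (4-nitrophenyl in place of 3-nitrophenyl on an oxygen on a saturated carbon). For the measured compounds named here, only one measured step bears on it, a 1.1-fold lower number from compound 1 to compound 2 (0.03 log units; within the scatter), for nitro in place of chloro on an aromatic carbon. That step changes the group and leaves its place untouched, so it bears only indirectly. Going by the values given here, no measured pair shows the effect of moving a group around the ring. With so little evidence, no step beyond the scatter is expected in this assay, and the estimated step is a 1.0-fold lower number from compound 2 to compound 3 (0.02 log units; within the scatter). For compound 3 the expected value is 5.5 nM, with an estimated range of 1.7 nM to 18 nM.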

Compound 3, half-maximal inhibitory concentration: 52 nM
Compound 3: the middle estimate sits 9.5-fold (0.98 log units) below what was measured; measured number outside the range, above it.
By their numbers in this assay, from the lowest: compounds 2 and 1 (each within the scatter of the next); then compound 3.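

In this assay, for the compounds shown here, the move from 3-nitrophenyl to 4-nitrophenyl on the same oxygen gives a 9.1-fold higher number from compound 2 to compound 3 (0.96 log units; beyond the scatter), the first step beyond the scatter, although the two groups have the same atoms and the same counts. The comparison with the 3-chlorophenyl group points the same way, with an 8.5-fold higher number from compound 1 to compound 3 (0.93 log units; beyond the scatter), so at this position the arrangement of the aromatic group matters in a way that the exchange of chloro for nitro did not show. No measurement among those shown accounts for this difference.

The compounds shown leave open whether the same move of chloro has a comparable effect. They also leave open how an amine or a carboxylic acid in place of nitro, or a longer chain, would read in this assay.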